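Proline Diethylamide in Place of the Glycinamide Urea

This account rests on a few compounds, and the source may have more. Where it says the series, first, only, none or still open, it means among the compounds named here.

Compound 3 `Cc1cc(C(=O)N2CCCCc3ccccc32)ccc1CNC(=O)NCC(=O)N1CCCC1` gives 100 nM in a functional assay on HEK293 cells for agonist activity at Vasopressin V2 receptor (Homo sapiens), read by a luciferase reporter and cAMP accumulation; a higher number here means that more compound is needed for the effect, a lower number that less compound is needed. It stands second highest of three numbers: compound 2 `Cc1cc(C(=O)N2CCCCc3ccccc32)ccc1CNC(=O)NCC(=O)N(C)C` gives 58 nM, and compound 1 `Cc1cc(C(=O)N2CCCCc3ccccc32)ccc1CNC(=O)NCC(=O)O` gives 180 nM, both within the scatter of compound 3. Compound 4 `CCN(CC)C(=O)[C@@H]1CCCN1C(=O)NCc1ccc(C(=O)N2CCCCc3ccccc32)cc1C` carries 2-(diethylcarbamoyl)pyrrolidin-1-yl in place of (((pyrrolidin-1-yl)carbonyl)methyl)amino on a carbonyl carbon. The measured steps at the same carbonyl carbon were a 3.1-fold lower number from compound 1 to compound 2 (0.49 log units; beyond the scatter) and a 1.8-fold lower number from compound 1 to compound 3 (0.26 log units; within the scatter), so changes at this position have shifted the number only modestly, with the amide of compound 2 at a lower number than the acid of compound 1. The step of a 1.4-fold lower number from compound 3 to compound 4 (0.15 log units; within the scatter) is therefore expected to be small, probably within the scatter. Compound 4 is estimated at 70 nM, with a range from 25 nM to 250 nM.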

Compound 4, half-maximal effective concentration: 350 nM
For compound 4 the middle estimate is 5.0-fold (0.70 log units) below the measured one; measured number outside the range, above it.
By their numbers in this assay, from the lowest: compounds 2, 3, 1 and 4 (each within the scatter of the next, the first and the last beyond it).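

In this assay, among these compounds, this is the first change at the carbonyl carbon to raise the number beyond the scatter: a 3.5-fold higher number from compound 3 to compound 4 (0.54 log units; beyond the scatter), and a 6.0-fold higher number from compound 2 to compound 4 (0.78 log units; beyond the scatter). The tertiary urea with its 2-(diethylcarbamoyl)pyrrolidin-1-yl group thus loses the gain that the simple amides showed over the acid, and it stands level with that acid: a 1.9-fold higher number from compound 1 to compound 4 (0.29 log units; within the scatter).

The compounds shown do not separate the pyrrolidine ring on the urea nitrogen, the diethylamide and the defined stereocentre, so a proline dimethylamide or an N-methylglycine dimethylamide would be needed to tell them apart. Nothing available explains the rise.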